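The source may hold more compounds than are shown below. What is called first, only, known or untested is meant among the compounds shown, and "the series" means these compounds.

Compound 1 `Cc1ccc(N(CCN2CCC(OCC(=O)O)CC2)C(=O)c2cccc(F)c2)cc1` and compound 2 `Cc1ccc(N(CCN2CCC(OCC(=O)O)CC2)C(=O)c2cccc(Cl)c2)cc1` share one core and differ in a single spot: chloro in place of fluoro on an aromatic carbon. In a functional assay on a cell-free system (Platelet, plasma, Homo sapiens) for inhibition (on this read-out lower numbers stand for stronger inhibition and higher numbers for weaker inhibition), compound 1 gives 160 nM, and compound 2 gives 100 nM. The step of a 1.6-fold lower number from compound 1 to compound 2 (0.20 log units; within the scatter) is therefore a small one. Compound 3 `O=C(O)COC1CCN(CCN(C(=O)c2ccc(F)cc2)c2ccc(Cl)cc2)CC1` is built on a different core, and the difference between the two cores is not broken down here. In this assay compound 3 gives 2000 nM, the highest of the three measured numbers, and its gap to compound 1 as well as to compound 2 lies beyond the scatter.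

Compound 4 `O=C(O)COC1CCN(CCN(C(=O)c2ccc(Cl)cc2)c2ccc(Cl)cc2)CC1` has not yet been measured. It is related to compound 3 by chloro in place of fluoro on an aromatic carbon. For the measured compounds named here, this is the same kind of change as the one from compound 1 to compound 2, but not the same change: in compound 1 the fluoro sits meta to a large group, whereas in compound 3 it sits para to a large group, and the core around it differs. Going by the values given here, the only guide is the earlier pair. The step to compound 4 is expected to be a 1.4-fold lower number from compound 3 to compound 4 (0.15 log units; within the scatter), because the matching change gave a 1.6-fold lower number from compound 1 to compound 2 (0.20 log units; within the scatter). Compound 4 is thus estimated to give about 1400 nM in this assay, with a likely range from 600 nM to 3500 nM.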

Compound 4, half-maximal inhibitory concentration: 1500 nM
Beside the measured number, compound 4's estimate is 1.1-fold (0.03 log units) below it; the measured number falls inside the stated range.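

In this assay, putting chloro in place of fluoro on the core of compound 3 gives a 1.3-fold lower number from compound 3 to compound 4 (0.12 log units; within the scatter), so on this second core, too, the swap leaves the number within the usual noise of the measurement. Set beside the earlier pair, the change reads alike on both cores: the same change on two cores in this assay, a 1.6-fold lower number (0.20 log units; within the scatter) from compound 1 to compound 2 and a 1.3-fold lower number (0.12 log units; within the scatter) from compound 3 to compound 4, 1.2-fold (0.08 log units) apart, within the scatter of two such steps This shows that, in these two pairs, the swap of fluoro for chloro carries over from one core to the other as a step too small to separate from the scatter, but it does not show a real gain from chloro on either core, and two pairs cannot establish a rule for the whole series or tell whether a change with a clear effect would carry over in the same way.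

Still open, as far as these compounds go, is whether a different group in the place of the halogen on the 4-chlorophenyl ring of compound 4, such as a methoxy group, a nitrile or a trifluoromethyl group, would give a step beyond the scatter. Also open, from the compounds shown here alone, is whether such a step would then be the same size on both cores, which is the test that these small steps cannot provide.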